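The source may hold more compounds than are shown below. What is called first, only, known or untested is meant among the compounds shown, and "the series" means these compounds.

Measured so far:
compound 1 `COc1cc2c(Nc3nc4ccc(C(=O)Nc5c(C)cc(C)cc5C)cc4s3)ncnc2cc1OCCCN1CCC(C)CC1` — 5400 nM
compound 2 `COc1cc2c(Nc3nc4ccc(C(=O)Nc5c(C)cccc5C)cc4s3)ncnc2cc1OCCCN1CCCCC1C` — 75700 nM

In a functional assay on A549 cells (Homo sapiens) for cytotoxicity, read by WST assay, with a stated time of 72 h (on this read-out higher numbers stand for weaker inhibition and lower numbers for stronger inhibition), compound 2 gives the highest of the two numbers; its nearest neighbour, compound 1, sits far lower, beyond the scatter. Compound 3 `COc1cc2c(Nc3nc4ccc(C(=O)Nc5c(C)cccc5C)cc4s3)ncnc2cc1OCCCN1CCC(C)CC1` is not yet measured. It differs from compound 2 by 4-methylpiperidin-1-yl in place of 2-methylpiperidin-1-yl on a saturated chain carbon, three bonds along the chain from an oxygen on an aromatic ring; the same atoms are joined differently. Compound 3 now carries the 4-methylpiperidin-1-yl that compound 1 also carries, while keeping the amide part of compound 2. Within the data shown here, no measured pair isolates this change, so the direction is not fixed by data; a step downward from compound 2 to compound 3 of a 3.0-fold lower number from compound 2 to compound 3 (0.48 log units; beyond the scatter) is expected, with wide uncertainty. Compound 3 is estimated at 25000 nM, within 6000 nM to 90000 nM.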

Compound 3, half-maximal inhibitory concentration: 89700 nM
Beside the measured number, compound 3's estimate is 3.6-fold (0.55 log units) below it; the range from low to high includes it.
By their numbers in this assay, from the lowest: compound 1; then compounds 2 and 3 (each within the scatter of the next).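

In this assay, 4-methylpiperidin-1-yl in place of 2-methylpiperidin-1-yl on the propyl chain gives (a 1.2-fold higher number from compound 2 to compound 3 (0.07 log units; within the scatter)), so these two methyl placements are not separated here. The large difference lies instead with hydrogen in place of methyl on an aromatic carbon (a 17-fold higher number from compound 1 to compound 3 (1.22 log units; beyond the scatter)), the first single change read on the amide part. No measured evidence accounts for either step.

Going by these compounds, whether the aromatic methyl step also holds with 2-methylpiperidin-1-yl remains open. So does the outcome with another amine, such as morpholine or dimethylamine, at the end of the propyl chain.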